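One added methyl on the lead compound

The source may report more compounds than this note shows. Statements on the series, on what has been measured and on what is new or still open speak of the compounds shown alone.

Measured so far in a functional assay on MCF7 cells (Homo sapiens) for cytotoxicity, read by CellTiter-Glo, with a stated time of 5 days; on this read-out higher numbers stand for weaker inhibition and lower numbers for stronger inhibition:
- compound 1 `CC/C(=C(/c1ccc(/C=C/C(=O)O)cc1)c1ccc2[nH]c(=O)oc2c1)c1ccccc1` gives 56 nM
- compound 2 `CC/C(=C(/c1ccc(/C=C/C(=O)O)cc1)c1ccc2[nH]ncc2c1)c1ccccc1` gives 6 nM

Compound 2 holds the lower of these two numbers, which makes it the stronger inhibitor of the pair. The next compound is compound 3 `CC/C(=C(\c1ccc2[nH]ncc2c1)c1ccc(/C=C/C(=O)O)cc1C)c1ccccc1`, and it differs from compound 2 in one place: methyl in place of hydrogen on an aromatic carbon, ortho to a large group and meta to a 2-carboxyethenyl group. For the measured compounds named here, only one measured step exists, a 9.3-fold lower number from compound 1 to compound 2 (0.97 log units; beyond the scatter), and it exchanged a different part of the molecule. That step shows that a single change can move the number in this assay beyond the scatter, but it says nothing about a methyl. No direction can be argued from these data, so no shift beyond the scatter is expected. The expected step is a 1.2-fold lower number from compound 2 to compound 3 (0.08 log units; within the scatter), which remains an estimate. Compound 3 is estimated at 5 nM (expected range 1.5 nM to 16 nM).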

Compound 3, half-maximal inhibitory concentration: 36 nM
For compound 3 the middle estimate is 7.2-fold (0.86 log units) below the measured one; the measured number lies above the stated range.
By their numbers in this assay, from the lowest: compound 2; then compounds 3 and 1 (each within the scatter of the next).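

Adding a single methyl to an aromatic carbon, ortho to a large group and meta to a 2-carboxyethenyl group, gives in this assay a 6.0-fold higher number from compound 2 to compound 3 (0.78 log units; beyond the scatter) and so moves the number beyond the scatter. For the compounds shown here, the earlier step changed a different part of the molecule, so this is the first sign that this aromatic carbon also matters, with hydrogen giving the stronger inhibition of the two. Nothing available explains why one added carbon moves the number this far.

Open, going by these compounds, is whether a fluorine atom, a methoxy group or an ethyl group on the same carbon would raise the number as the methyl does, or leave it unchanged. Also open, on these data alone, is whether the same methyl would shift the number in the same direction on the core of compound 1.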